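A few compounds are considered here, and "the series" means these few. Any claim that something is new, unique, unknown or untested is made for them only; others in the source may bear on it.

Measured compounds:
- compound 1 `COc1cc(CCc2ccccn2)cc(OC)c1O`: > 25000 nM
- compound 2 `COc1cc(CCc2ccncc2)cc(OC)c1O`: > 25000 nM

In a functional assay on A549 cells (Homo sapiens) for antiproliferative activity, read by MTT assay, with a stated time of 72 h (a lower number here means a stronger inhibitor, a higher number a weaker inhibitor), compound 1 gives > 25000 nM, which is a limit of the assay and not a number. Compound 2 gives > 25000 nM, which is also a limit. Compound 3 `COc1cc(CCc2ccccc2)cc(OC)c1O` has not yet been measured. It keeps the core of compound 1 and carries phenyl in place of pyridin-2-yl on a saturated chain carbon, two bonds along the chain from an aromatic carbon.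

Within the data shown here, the one measured step that bears on this also changes the same ring, and its size cannot be read: a step that the two limits leave unreadable from compound 1 to compound 2. All the evidence so far sits at one limit: the limit of > 25000 nM in this assay, at which 2 of the 2 values shown sit. Among the measured compounds shown here, no measured step therefore shows a gain, so no clear step in this assay is expected, and any direction is uncertain. For compound 3 the expected value is 30000 nM, with an estimated range from 10000 nM to 60000 nM. The expected step is a step that the limit leaves unreadable from compound 1 to compound 3.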

Compound 3, half-maximal inhibitory concentration: 10900 nM
Beside the measured number, compound 3's estimate is 2.8-fold (0.44 log units) above it, and the stated range covers the measured number.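

In this assay, the change to phenyl gives an at least 2.2-fold lower number from compound 1 to compound 3 (0.36 log units; beyond the scatter) and an at least 2.2-fold lower number from compound 2 to compound 3 (0.36 log units; beyond the scatter). Among these compounds, these are the first readable steps at this position: a ring of carbon only on the chain gives a lower number than either nitrogen-bearing ring, whereas the step between the two pyridinyl compounds cannot be read. The true sizes of both steps remain unknown because the values of compound 1 and compound 2 are limits of the assay: the limit of > 25000 nM in this assay, at which 2 of the 3 values shown sit.

The compounds shown do not tell whether the place of the ring nitrogen matters, since neither pyridinyl compound gives a number. They also leave open how a phenyl ring carrying an amine or a carboxylic acid, or a longer chain linking the ring to the shared core, would read in this assay.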